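Dropping the Glycyl Group from Compound 2

The source may report more compounds than this note shows. Statements on the series, on what has been measured and on what is new or still open speak of the compounds shown alone.

Three compounds have numbers in an assay on a protein complex (K562 cells) for inhibition of integrin alpha-5/beta-1 (Homo sapiens), with stated times of 30 min and 1 h; on this read-out lower numbers stand for stronger inhibition and higher numbers for weaker inhibition. Compound 1 `CCCN(C(=O)CC(=O)O)C1=C(C)CC(c2ccccc2)N([C@@H](C)c2ccc(N)cc2)C1=O` gives 57 nM, the lowest of the three. Compound 2 `C/C=C(\C(=O)NCC(=O)O)C(NCc1ccc(NC(=O)CN)cc1)C(C)C` gives 170 nM and stands second highest; its gap to compound 1 lies beyond the scatter, as does its larger gap to compound 3. Compound 3 `CC1=C(C(=O)NCc2ccc(N)cc2)C(C(C)C)N(C(=O)CC(=O)O)O1` gives 1050 nM, the highest number of the set.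

Compound 4 `C/C=C(\C(=O)NCC(=O)O)C(NCc1ccc(N)cc1)C(C)C` is not yet measured. It differs from compound 2 in a single place: hydrogen in place of (aminomethyl)carbonyl on a nitrogen on an aromatic ring. Among the compounds with values here, no pair of measured compounds shows this exchange directly. Compounds 1 and 3 both carry the free amino group that compound 4 would carry, yet one sits well below compound 2 and the other well above it, so they point in no single direction.

The step from compound 2 to compound 4 is therefore expected to be small, around a 1.3-fold higher number from compound 2 to compound 4 (0.11 log units; within the scatter) in this assay, with no clear movement beyond the scatter. Compound 4 is estimated at 220 nM, within a range from 70 nM to 700 nM.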

Compound 4, half-maximal inhibitory concentration: 220 nM
Compound 4: middle estimate and measured number agree at the digits printed, within the range that was stated.
By their numbers in this assay, from the lowest: compound 1; then compounds 2 and 4 (each within the scatter of the next); then compound 3.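

Within the data shown here, the pair gives the first direct reading of this change, which compounds 1 and 3 could not supply: with hydrogen in place of (aminomethyl)carbonyl on a nitrogen on an aromatic ring, this assay shows a 1.3-fold higher number from compound 2 to compound 4 (0.11 log units; within the scatter) and no movement beyond the scatter. On this core, then, all four heavy atoms of that group can leave the nitrogen without a measurable difference in this read-out. Nothing measured here explains why the exchange leaves the number within the scatter.

On these data alone, it remains open whether an acetyl group or a longer aminoacyl chain on the same nitrogen would shift the number beyond the scatter. Also open is whether the amino group itself matters, since no compound shown replaces it with a methyl group or a hydroxyl group.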